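The compounds below may be only part of what the source reports. "The series", "measured", "known", "first", "only" and "open" are said of these compounds alone.

The three measured compounds share one core and differ only in the group carried on a nitrogen on an aromatic ring. Compound 1 `CCCCOc1ccc(-c2nc3ncccn3c2NC2CCCCCC2)cc1` bears a cycloheptyl there, and in a toxicity assay on A549 cells (Homo sapiens) for cytotoxicity, read by luminescence and CellTiter-Glo, with a stated time of 48 h (on this read-out higher numbers stand for lower toxicity in this test and lower numbers for higher toxicity in this test), compound 1 gives 26000 nM. Compound 2 `CCCCOc1ccc(-c2nc3ncccn3c2NC(C)C)cc1` bears an isopropyl, and in this assay compound 2 gives 68000 nM. Compound 3 `CCCCOc1ccc(-c2nc3ncccn3c2NCC2CC2)cc1` bears a cyclopropylmethyl. In this assay compound 3 reaches only a limit of the assay, > 100000 nM, so for it there is a floor rather than a number. That floor is the one noted as the limit of > 100000 nM in this assay, at which 1 of the 3 values shown sits. On the numbers shown, compound 3 stands at the top: an at least 3.8-fold higher number from compound 1 to compound 3 (0.58 log units; beyond the scatter) and an at least 1.4-fold higher number from compound 2 to compound 3 (0.16 log units; that floor lies within the scatter). Between the two numbered compounds the step of a 2.6-fold higher number from compound 1 to compound 2 (0.42 log units; beyond the scatter) was modest.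

The unmeasured compound 4 `CCCCOc1ccc(-c2nc3ncccn3c2Nc2ccc(F)cc2)cc1` alters the same place: 4-fluorophenyl in place of cyclopropylmethyl on a nitrogen on an aromatic ring. Among the compounds with values here, none of the measured steps put an aromatic group on this nitrogen, so they bear on the new change only loosely. The measured steps ran upward as the cycloheptyl gave way to smaller groups; a 4-fluorophenyl is a return to a larger group, so the number for compound 4 is expected to come down from the floor of compound 3, as an at least 2.5-fold lower number from compound 3 to compound 4 (0.39 log units; beyond the scatter). Compound 4 is therefore estimated at 40000 nM, within a range from 15000 nM to 100000 nM.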

Compound 4, half-maximal cytotoxic concentration: > 100000 nM
Compound 4: no number, only a limit; the forecaster's own chance of this, stated with the estimate: 35%; at least 2.5-fold (0.39 log units) between middle value and limit.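

With a 4-fluorophenyl on the nitrogen, the first aromatic group shown at this position, compound 4 reaches a limit of this assay and gives no number. Replacing the cycloheptyl with this group reads as an at least 3.8-fold higher number from compound 1 to compound 4 (0.58 log units; beyond the scatter), while replacing the isopropyl reads as an at least 1.4-fold higher number from compound 2 to compound 4 (0.16 log units; that floor lies within the scatter), so only the first of these floors clears the scatter. The rise seen as the cycloheptyl gave way to smaller groups therefore does not hold for every group at this position, since compound 4 goes against it, and the step from compound 3 to compound 4 cannot be read, as both compounds give only a limit: the limit of > 100000 nM in this assay, at which 2 of the 4 values shown sit.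

As far as these compounds go, how far compound 3 and compound 4 lie past that limit stays open, so the two cannot be ordered, and a higher top concentration would be needed to separate them. Also open, from the compounds shown here alone, is whether the fluorine plays any part, and whether a plain phenyl, a benzyl or a pyridyl on this nitrogen would likewise stay at the limit or would bring the number down towards that of compound 1.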